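The source may hold more compounds than are shown below. What is called first, only, known or untested is meant among the compounds shown, and "the series" means these compounds.

The measured compounds so far:

compound 1, `CC(C)(C)N(NC(=O)c1ccc(Br)cc1)C(=O)c1ccccc1Cl` – 33.9 nM
compound 2, `Cc1ccc(C(=O)NN(C(=O)c2ccccc2Cl)C(C)(C)C)cc1` – 18.6 nM

Both were tested in an assay on cells for agonist activity at ecdysone receptor (Bombyx mori), read by a luciferase reporter, with a stated time of 24 h; on this read-out higher numbers stand for an effect only at larger amounts of compound and lower numbers for an effect already at smaller amounts. For the measured compounds named here, compound 2 stands at the lower of the two numbers, but its only point of comparison is compound 1, and the step of a 1.8-fold lower number from compound 1 to compound 2 (0.26 log units; within the scatter) lies within the usual scatter, so the two compounds are not separated by this read-out. The change that produced this step is a methyl in place of a bromo on the ring that carries the amide hydrogen, and it says nothing about the other ring.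

Compound 3, `Cc1ccc(C(=O)NN(C(=O)c2cc(C)cc(C)c2)C(C)(C)C)cc1`, is not yet measured. It differs from compound 2 in that other ring: 3,5-dimethylphenyl in place of 2-chlorophenyl on a carbonyl carbon. Going by the values given here, no measured step touches this position, so the size and direction of the coming step cannot be read from the data, and any expectation rests on little. Compound 3 is therefore expected to give 6 nM in this assay, within a wide range from 1.5 nM to 25 nM. That estimate means a step of a 3.1-fold lower number from compound 2 to compound 3 (0.49 log units; beyond the scatter), held loosely.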

Compound 3, half-maximal effective concentration: 12 nM
Compound 3: the middle estimate sits 2.0-fold (0.30 log units) below what was measured; low and high end bracket the measured number.
By their numbers in this assay, from the lowest: compounds 3, 2 and 1 (each within the scatter of the next, the first and the last beyond it).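

In this assay, 3,5-dimethylphenyl in place of 2-chlorophenyl on a carbonyl carbon gives a 1.6-fold lower number from compound 2 to compound 3 (0.19 log units; within the scatter), so this first change at the position does not separate the two compounds on this read-out. The entering group has two methyl groups and no chlorine, yet the two numbers remain within the usual scatter, so among the compounds shown, a number of this size does not depend on the chlorine of compound 2. No measurement is available that would explain why these two groups read alike.

The compounds shown leave open how this position would respond to a ring carrying a methoxy group, an amine or a carboxylic acid, since both groups seen here are six-membered aromatic rings of carbon only. They also leave open whether a change at this position and a change on the ring that carries the amide hydrogen add up when combined, or whether the outcome at one place depends on the group at the other.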